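Ethyl for ethoxy on the core, dichlorophenyl series

A few compounds are considered here, and "the series" means these few. Any claim that something is new, unique, unknown or untested is made for them only; others in the source may bear on it.

Of the compounds shown here, two of the shared core have numbers so far. Compound 1 `CCc1nc(-c2ccc(OC)cc2OC(F)(F)F)c(CC)nc1NC(CC)CC`, carrying an ethyl on the core, gives 4.1 nM in an assay on IMR-32 cells for displacement of a labelled ligand from corticotropin-releasing factor receptor 1 (Homo sapiens), read by scintillation counting, with a stated time of 2 h; a lower number here means a stronger inhibitor, a higher number a weaker inhibitor. Compound 2 `CCOc1nc(-c2ccc(Cl)cc2Cl)c(CC)nc1NC(CC)CC`, with an ethoxy at the same place and a 2,4-dichlorophenyl group, gives 151 nM in this assay. Compound 2 thus stands at the higher of the two numbers, and the gap to compound 1 lies well beyond the scatter; since the two compounds differ at more than one place, the gap cannot be split between the two changes.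

Compound 3 `CCc1nc(-c2ccc(Cl)cc2Cl)c(CC)nc1NC(CC)CC` is not yet measured. It differs from compound 2 in one place: ethyl in place of ethoxy on an aromatic carbon. The change puts the ethyl of compound 1 onto the dichlorophenyl-bearing core of compound 2.

Going by the values given here, no single step between measured compounds covers this change. Because compound 1 gives 4.1 nM with the ethyl in place, a drop beyond the scatter is expected for the step of a 6.0-fold lower number from compound 2 to compound 3 (0.78 log units; beyond the scatter) in this assay. For compound 3 the value expected in this assay is 25 nM, estimated within 6 nM to 100 nM.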

Compound 3, inhibition constant: 4.1 nM
Estimate against measurement, compound 3: 6.1-fold (0.79 log units) above; measured number below the stated range.
By their numbers in this assay, from the lowest: compounds 1 and 3 (each within the scatter of the next); then compound 2.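

In this assay, ethyl in place of ethoxy gives a 37-fold lower number from compound 2 to compound 3 (1.57 log units; beyond the scatter), the first single change read at this position, next to the ring nitrogen and ortho to the (pentan-3-yl)amino group, with the 2,4-dichlorophenyl group held fixed. With the ethyl in place, compound 3 at 4.1 nM and compound 1 at 4.1 nM lie within the scatter of each other, so the two different aryl groups show no separable difference on this ethyl core, and the gap that could not be split earlier now has a single change of the same size in the dichlorophenyl series. Nothing in hand accounts for the size of this step, whether from the lost oxygen or from anything else about the two groups.

Open, going by these compounds, is how a methyl, a propyl chain or a dimethylamino group at this position would stand against the ethyl and the ethoxy. Also open, on these data alone, is whether the step carries over to the aryl group of compound 1, as it is read so far in the 2,4-dichlorophenyl series alone.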